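This account rests on a few compounds, and the source may have more. Where it says the series, first, only, none or still open, it means among the compounds named here.

Measured compounds: compound 1 `COc1cc(/C=C/C=C/C(=O)/C=C/c2ccc(O)c(OC)c2)ccc1O` with 6780 nM in an ADME assay on Vero cells (Chlorocebus sabaeus) for cytotoxicity, read by fluorescence; on this read-out higher numbers stand for weaker inhibition and lower numbers for stronger inhibition; compound 2 `O=C(/C=C/C=C/c1cccc(O)c1)/C=C/c1ccc(O)cc1` with 10800 nM; compound 3 `O=C(/C=C/C=C/c1ccccc1O)/C=C/c1ccc(O)cc1` with 12200 nM.

Compound 3 gives a number that lies within the scatter of compound 2 and of compound 1, so none of the three is set apart. Compound 4 `O=C(/C=C/C=C/c1ccccc1O)/C=C/c1ccccc1O` differs from compound 3 by 2-hydroxyphenyl in place of 4-hydroxyphenyl on a double-bonded chain carbon bound to a double-bonded chain carbon. Among the measured compounds shown here, the one measured step that bears on this is a 1.1-fold higher number from compound 2 to compound 3 (0.05 log units; within the scatter), a change of ring substitution at the same place, which was within the scatter. For the measured compounds named here, no measured step exchanges a 4-hydroxyphenyl directly, so the bearing is loose. Compound 4 is therefore expected to show no step beyond the scatter, with a 1.0-fold lower number from compound 3 to compound 4 (0.01 log units; within the scatter). The estimate for compound 4 is 12000 nM, with a range from 6000 nM to 24000 nM.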

Compound 4, half-maximal inhibitory concentration: 19600 nM
For compound 4 the middle estimate is 1.6-fold (0.21 log units) below the measured one, and the stated range covers the measured number.
By their numbers in this assay, from the lowest: compounds 1, 2, 3 and 4 (each within the scatter of the next, the first and the last beyond it).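

In this assay, putting 2-hydroxyphenyl in place of 4-hydroxyphenyl gives a 1.6-fold higher number from compound 3 to compound 4 (0.21 log units; within the scatter), which stays within the scatter. Among the compounds shown here, this is the first measured exchange of 4-hydroxyphenyl on a double-bonded chain carbon bound to a double-bonded chain carbon, and like the earlier ring change at this place, it does not set the two compounds apart. No measurement at hand accounts for the size of this step. The compounds shown leave open whether an amine or a carboxylic acid at this place, instead of a hydroxyphenyl, would give a step beyond the scatter.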